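Adding chlorine to a diaminoquinazoline dihydrofolate reductase inhibitor

A few compounds are considered here, and "the series" means these few. Any claim that something is new, unique, unknown or untested is made for them only; others in the source may bear on it.

Measured compounds:
compound 1 `Cc1cc2ncn(-c3ccc4c(N)nc(N)nc4c3)c2cc1C` 1610 nM
compound 2 `Cc1cc2nc(-c3cccs3)n(-c3ccc4c(N)nc(N)nc4c3)c2cc1C` 1030 nM
compound 3 `Cc1cc2nc(C3CC3)n(-c3ccc4c(N)nc(N)nc4c3)c2cc1C` 1160 nM

In an assay on isolated protein for inhibition of Dihydrofolate reductase (Homo sapiens), read by spectrophotometry, using NADPH, with a stated time of 10 min (a lower number here means a stronger inhibitor, a higher number a weaker inhibitor), compound 1 gives 1610 nM, compound 2 gives 1030 nM and compound 3 gives 1160 nM. Going by the values given here, the three numbers lie close together: the step of a 1.6-fold lower number from compound 1 to compound 2 (0.19 log units; within the scatter), the step of a 1.4-fold lower number from compound 1 to compound 3 (0.14 log units; within the scatter) and the step of a 1.1-fold higher number from compound 2 to compound 3 (0.05 log units; within the scatter) are all within the scatter, so no compound can be called stronger or weaker than another. Compound 2 has the lowest number of the three, but only by a margin that repeated measurement could erase.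

Compound 4 `Cc1cc2nc(-c3cccs3)n(-c3cc4nc(N)nc(N)c4cc3Cl)c2cc1C` has not been measured. Compared with compound 2 it carries chloro in place of hydrogen on an aromatic carbon; the new group sits on an aromatic carbon of a six-membered aromatic ring of carbon only, part of a fused or bridged system of two rings, ortho to a large group, meta to a fused ring and para to a fused ring. Among the compounds with values here, none of the measured steps touches this ring, so no step bears on the change, and the expectation rests on the values alone. The step of a 1.3-fold lower number from compound 2 to compound 4 (0.11 log units; within the scatter) is expected to stay within the scatter. Compound 4 is estimated at 800 nM, with a range from 250 nM to 2500 nM.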

Compound 4, inhibition constant: > 3000 nM
Compound 4 was reported as a limit; the forecaster's own chance of this, stated with the estimate: 3%; middle value at least 3.7-fold (0.57 log units) from the limit.
By their numbers in this assay, from the lowest: compounds 2, 3 and 1 (each within the scatter of the next). At a limit, above all of these: compound 4.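

The earlier steps shown here all lay elsewhere in the molecule and stayed within the scatter, so they gave no sign of any place where a small change matters. Going by these compounds alone, this position, on a six-membered aromatic ring of carbon only and ortho to a large group, is the first where a single change reaches beyond the scatter: an at least 2.9-fold higher number from compound 2 to compound 4 (0.46 log units; beyond the scatter). Chloro, a single heavy atom in place of hydrogen, is therefore enough to make this inhibitor weaker, and the value of compound 4 is a limit of the assay, not a number: the limit of > 3000 nM in this assay, at which 1 of the 4 values shown sits.

As far as these compounds go, how far compound 4 truly lies from compound 2 stays unknown, and the finding rests on this one pair, so it is open whether chloro acts the same way with the cyclopropyl group of compound 3. Also open, from the compounds shown here alone, is how a methyl group, a methoxy group or an amine would fare at this same place.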